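The compounds below may be only part of what the source reports. "The series", "measured", "known", "first", "only" and "open" are said of these compounds alone.

Measured compounds:
- compound 1, `CN1CCN(CC(=O)Nc2nc3ccccc3[nH]2)CC1`: 45%
- compound 2, `O=C(CN1CCN(c2ccccc2)CC1)Nc1nc2ccccc2[nH]1`: 32.2%
- compound 3, `O=C(CN1CCN(c2ccccn2)CC1)Nc1nc2ccccc2[nH]1`: 57.3%

In a functional assay, read by spectrophotometry, with a stated time of 30 min, tested at 100 ug/mL (on this read-out lower numbers stand for a weaker effect and higher numbers for a stronger effect at the one concentration tested), compound 3 stands highest of the three. Its lead over compound 1 is a number 12.3 percentage points higher from compound 1 to compound 3 (beyond the scatter) and its lead over compound 2 is a number 25.1 percentage points higher from compound 2 to compound 3 (beyond the scatter), both beyond the scatter. Between the other two, the move from compound 1 to compound 2 gave a number 12.8 percentage points lower from compound 1 to compound 2 (beyond the scatter).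

Compound 4, `O=C(CN1CCN(c2ncccn2)CC1)Nc1nc2ccccc2[nH]1`, has not yet been measured in this assay. It differs from compound 3 in one place: pyrimidin-2-yl in place of pyridin-2-yl on an amine nitrogen in a ring. Within the data shown here, no measured step covers exactly this exchange. Among the measured compounds shown here, the step that comes nearest is the one from compound 2 to compound 3, where a phenyl gave way to a pyridin-2-yl on the same amine nitrogen in a ring and the read-out rose by a number 25.1 percentage points higher from compound 2 to compound 3 (beyond the scatter); the step from compound 1 to compound 3 rose by a number 12.3 percentage points higher from compound 1 to compound 3 (beyond the scatter). A second ring nitrogen entering the same group is a smaller change than either of those, so compound 4 is expected to sit near compound 3, with a step of a number 3.7 percentage points higher from compound 3 to compound 4 (within the scatter) that may stay within the scatter. The estimate for compound 4 in this assay is 61%, with a range from 45% to 77%.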

Compound 4, a percentage reported as activity, at one concentration (the size of the read-out at that concentration, not a potency): 46.5%
Compound 4: the middle estimate sits 14.5 percentage points above what was measured, and the stated range covers the measured number.
By their numbers in this assay, from the lowest: compound 2; then compounds 1 and 4 (each within the scatter of the next); then compound 3.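

In this assay, the rise seen when a ring nitrogen entered the aromatic group on this amine nitrogen in a ring did not continue with a second one: pyrimidin-2-yl in place of pyridin-2-yl gave a number 10.8 percentage points lower from compound 3 to compound 4 (beyond the scatter), so among these three groups the read-out does not climb with the number of hetero atoms in the ring. Pyrimidin-2-yl in place of phenyl still gave a number 14.3 percentage points higher from compound 2 to compound 4 (beyond the scatter), which means that both nitrogen-bearing aromatic groups, in compound 3 and compound 4, keep a lead over the all-carbon ring of compound 2, and that the one with a single hetero atom reads best of the three. Pyrimidin-2-yl in place of methyl gave a number 1.5 percentage points higher from compound 1 to compound 4 (within the scatter), so at this position and this one concentration, the large aromatic group of compound 4 cannot be told apart from the small methyl of compound 1.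

Nothing at hand explains why the second ring nitrogen lowers the read-out. The compounds shown also leave open how a benzyl group, a longer alkyl chain or a carboxylic acid on the same amine nitrogen would compare with these groups.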